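Cyclobutyl to oxetan-3-yl on the sulfonamide nitrogen

This account rests on a few compounds, and the source may have more. Where it says the series, first, only, none or still open, it means among the compounds named here.

Among the compounds with values here, in a physicochemical assay for lipophilicity, at pH 7.4 (on this read-out higher numbers stand for higher lipophilicity and lower numbers for lower lipophilicity), compound 2 `CCc1ccc(N(C2CCC2)S(=O)(=O)c2ccc3c(c2)C(=O)CC(C2CCOCC2)O3)cc1` gives 3.78, the lower of the two numbers measured so far, while compound 1 `CCc1ccc(N(CC2CCC2)S(=O)(=O)c2ccc3c(c2)C(=O)CC(C2CCOCC2)O3)cc1` gives 4.1. The next compound to be measured is compound 3 `CCc1ccc(N(C2COC2)S(=O)(=O)c2ccc3c(c2)C(=O)CC(C2CCOCC2)O3)cc1`, which carries oxetan-3-yl in place of cyclobutyl on a sulfonamide nitrogen. Within the data shown here, only one measured step bears on this place: a number 0.32 log units lower from compound 1 to compound 2 (beyond the scatter), a modest step beyond the scatter. Among the measured compounds shown here, that step exchanges no ring carbon for a hetero atom, so it serves only as a loose guide to size, and the series holds no direct precedent for this change. The step expected in this assay points downward and is expected to be larger than that one, with an estimate of a number 0.93 log units lower from compound 2 to compound 3 (beyond the scatter). Compound 3 is expected at 2.85, within an estimated range of 2.4 to 3.3.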

Compound 3, distribution coefficient: 2.72
Compound 3: the middle estimate sits 0.13 log units above what was measured; measured number inside the range.
By their numbers in this assay, from the lowest: compound 3; then compound 2; then compound 1.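

In this assay, oxetan-3-yl in place of cyclobutyl on a sulfonamide nitrogen gives a large step (a number 1.06 log units lower from compound 2 to compound 3 (beyond the scatter)), with 4 heavy atoms in both groups and one hydrogen-bond acceptor entering. The earlier step at this place (a number 0.32 log units lower from compound 1 to compound 2 (beyond the scatter)) was modest and brought in no hetero atom, so this position is now shown to respond strongly to a ring oxygen at unchanged heavy-atom count. Measured from the cyclobutylmethyl group, the change is also large (a number 1.38 log units lower from compound 1 to compound 3 (beyond the scatter)), and nothing at hand accounts for the size of either step. Within the data shown here, only one hetero-atom ring appears at this place, so whether an azetidine ring or a tetrahydrofuran ring would give a similar step stays open. Also open, from the compounds shown here alone, is how oxetan-3-ylmethyl would compare directly with the cyclobutylmethyl group of compound 1.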